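Moving a halogen on the outer phenyl ring

A few compounds are considered here, and "the series" means these few. Any claim that something is new, unique, unknown or untested is made for them only; others in the source may bear on it.

Compound 1, `Cc1ncc(C)n2nc(-c3ccc4nc(-c5ccccc5)[nH]c4c3)nc12`, in an ADME assay on microsomes from liver (Rattus norvegicus) for metabolic stability, read by LC-MS, in the presence of a further agent that is not named here (on this read-out higher numbers stand for fast clearance and lower numbers for slow clearance), gives 27.4 mL.min-1.g-1.
Compound 2, `Cc1ncc(C)n2nc(-c3ccn4cc(-c5cccc(Cl)c5)nc4n3)nc12`, in this assay gives 18.9 mL.min-1.g-1.
Compound 3, `Cc1ncc(C)n2nc(-c3ccc4nc(-c5ccco5)[nH]c4c3)nc12`, in this assay gives 26.3 mL.min-1.g-1.

All three numbers lie within the usual scatter of one another, so compound 2 cannot be set apart from compound 1 or from compound 3 on what has been measured; its value simply sits among theirs. Among the compounds with values here, the one measured step, a 1.0-fold lower number from compound 1 to compound 3 (0.02 log units; within the scatter), alters a group on a different part of the molecule from the one changed here, and it too stays within the scatter.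

Compound 4, `Cc1ncc(C)n2nc(-c3ccn4cc(-c5ccc(Br)cc5)nc4n3)nc12`, differs from compound 2 in one place: 4-bromophenyl in place of 3-chlorophenyl on an aromatic carbon. Within the data shown here, no measured step exchanges one halogenated phenyl for another, so nothing here bears directly on this change. Among the measured compounds shown here, the only guide is that the three measured compounds, which carry different outer rings, all fall within the scatter of one another in this assay. The step of a 1.1-fold higher number from compound 2 to compound 4 (0.05 log units; within the scatter) is therefore expected to lie within the scatter, in no particular direction. The estimate for compound 4 in this assay is 21 mL.min-1.g-1, with a range from 10 mL.min-1.g-1 to 42 mL.min-1.g-1.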

Compound 4, intrinsic clearance in microsomes: 15 mL.min-1.g-1
Compound 4: middle estimate off by 1.4-fold (0.15 log units), on the high side; the range from low to high includes it.
By their numbers in this assay, from the lowest: compounds 4, 2, 3 and 1 (each within the scatter of the next).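

Placed side by side in this assay, two halogenated phenyl groups on this aromatic carbon can now be compared directly, and the step of a 1.3-fold lower number from compound 2 to compound 4 (0.10 log units; within the scatter) stays within the scatter. At this position, then, 3-chlorophenyl and 4-bromophenyl cannot be told apart on this read-out, even though the halogen and its place on the phenyl ring both differ in this one exchange. No measured evidence is available here that bears on what lies behind this result.

The compounds shown leave open how the halogen and its place on the phenyl ring each contribute, as this single pair alters both together and two such effects could be small on their own or could offset each other. Also open, going by these compounds, is whether a phenyl ring carrying an amine or a carboxylic acid in place of the halogen would still fall within the scatter of these two compounds in this assay.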